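A few compounds are considered here, and "the series" means these few. Any claim that something is new, unique, unknown or untested is made for them only; others in the source may bear on it.

In an ADME assay on L929 cells (Mus musculus) for cytotoxicity, read by resazurin assay, with a stated time of 72 h (on this read-out higher numbers stand for weaker inhibition and lower numbers for stronger inhibition), compound 1 (`O=C(/C=C/c1ccc2c(c1)B(O)OC2)c1ccccc1`) gives > 10 ug/mL as its reading, which is a limit and not a number. Compound 2 (`O=C(/C=C/c1ccc2c(c1)B(O)OC2)c1ccc(F)cc1`) gives > 10 ug/mL as its reading, again only a limit, so it has no exact value. All that the series holds so far is the limit of > 10 ug/mL in this assay, at which 2 of the 2 values shown sit, and nothing more exact.

Compound 3 (`O=C(/C=C/c1ccc2c(c1)B(O)OC2)c1ccc(I)cc1`) changes one group: iodo in place of fluoro on an aromatic carbon. Within the data shown here, the only measured step is a step that the two limits leave unreadable from compound 1 to compound 2 and it gives no size to carry forward, so no step beyond the scatter is expected in this assay and no direction can be argued. The estimated change is a step that the limit leaves unreadable from compound 2 to compound 3 and it carries no firm direction. The estimate for compound 3 is 12 ug/mL within an expected range of 4 ug/mL to 30 ug/mL and a reading that is again only a limit would fit it.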

Compound 3, half-maximal inhibitory concentration: > 10 ug/mL
Compound 3: a limit, no number (the forecaster's own chance of this, stated with the estimate: 65%); the middle value does not contradict the limit.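

No step can be read among compound 1, compound 2 and compound 3 in this assay, since each reading is a limit and not a number: the limit of > 10 ug/mL in this assay, at which 3 of the 3 values shown sit. The compounds shown leave open whether hydrogen, fluoro or iodo at this place makes any difference to cytotoxicity.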